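The source may hold more compounds than are shown below. What is called first, only, known or untested is meant among the compounds shown, and "the series" means these compounds.

Compounds 1, 2 and 3 share a single core and differ only in the group on an aromatic carbon. Compound 1 `O=C(Nc1cccc(Br)c1)N[C@@H]1C2CCN(CC2)[C@@H]1Cc1cccnc1` carries a bromo group; in an assay on a protein complex for binding affinity to Neuronal acetylcholine receptor; alpha4/beta2 (Homo sapiens) (a lower number here means a stronger inhibitor, a higher number a weaker inhibitor), compound 1 gives > 10000 nM, which is a limit of the assay rather than a number. Compound 2 `COc1cccc(NC(=O)N[C@@H]2C3CCN(CC3)[C@@H]2Cc2cccnc2)c1` carries a methoxy group, and in this assay compound 2 gives > 10000 nM, again a limit. Compound 3 `O=C(Nc1cccc(F)c1)N[C@@H]1C2CCN(CC2)[C@@H]1Cc1cccnc1` carries a fluoro group, and in this assay compound 3 gives > 10000 nM, also a limit. Compound 3 therefore stands where the other two stand, as the limit of > 10000 nM in this assay, at which 3 of the 3 values shown sit, records. The three steps among them, a step that the two limits leave unreadable from compound 1 to compound 2, a step that the two limits leave unreadable from compound 1 to compound 3 and a step that the two limits leave unreadable from compound 2 to compound 3, cannot be sized from these limits. Compound 4 `O=C(Nc1cccc(C(F)(F)F)c1)N[C@@H]1C2CCN(CC2)[C@@H]1Cc1cccnc1` differs from compound 3 by trifluoromethyl in place of fluoro on an aromatic carbon. For the measured compounds named here, none of the measured steps can be read for size or direction, so no step beyond the scatter can be predicted from them. Compound 4 is expected to give 20000 nM, in the range 8000 nM to 80000 nM, most likely reported once more as a limit. This expectation amounts to a step that the limit leaves unreadable from compound 3 to compound 4.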

Compound 4, inhibition constant: > 10000 nM
Compound 4: a limit, no number (the forecaster's own chance of this, stated with the estimate: 85%); the middle value does not contradict the limit.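

In this assay compound 4 also gives a limit rather than a number, so its steps to compound 1, compound 2 and compound 3 cannot be read. The compounds shown leave open how these four groups rank, and whether any of them gives a measurable value, as all four compounds stand at one point: the limit of > 10000 nM in this assay, at which 4 of the 4 values shown sit.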